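The source may report more compounds than this note shows. Statements on the series, on what has been measured and on what is new or still open speak of the compounds shown alone.

Going by the values given here, compound 3 `C[C@@H](Oc1cc2oc(=O)n(CCC(=O)O)c2cc1Cl)c1cccnn1` gives 631 nM in an assay on HEK293 cells for inhibition of kynurenine 3-monooxygenase (Homo sapiens), read by LC-MS, with a stated time of 20 h (a lower number here means a stronger inhibitor, a higher number a weaker inhibitor), which places it second highest of the three numbers so far; its nearest neighbour is compound 2 `C[C@@H](Oc1cc2oc(=O)n(CCC(=O)O)c2cc1Cl)c1ccc(Cl)cn1`, which gives 100 nM in this assay, and furthest from it is compound 1 `O=C(O)CCn1c(=O)oc2cc(OCc3ccccn3)c(Cl)cc21`, which gives 5010 nM.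

The unmeasured compound 4 `C[C@@H](Oc1cc2oc(=O)n(CCC(=O)O)c2cc1Cl)c1ncccn1` differs from compound 3 in one place: pyrimidin-2-yl in place of pyridazin-3-yl on a saturated chain carbon bound to an oxygen on an aromatic ring and a saturated chain carbon. The two measured steps that touch this position are a 7.9-fold lower number from compound 1 to compound 3 (0.90 log units; beyond the scatter) and a 6.3-fold higher number from compound 2 to compound 3 (0.80 log units; beyond the scatter). Both are modest and both concern the aromatic ring on the saturated chain carbon bound to the oxygen on the aromatic ring, but neither compares two six-membered aromatic rings with two hetero atoms against each other, so they set the scale of what such a change can do rather than its direction.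

The exchange of one such ring for the other is therefore expected to move the number little, with the step from compound 3 to compound 4 estimated as a 1.3-fold lower number from compound 3 to compound 4 (0.10 log units; within the scatter). For compound 4 the estimated value in this assay is 500 nM, within a range from 160 nM to 1600 nM.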

Compound 4, half-maximal inhibitory concentration: 3160 nM
Beside the measured number, compound 4's estimate is 6.3-fold (0.80 log units) below it, outside the stated range (above it).
By their numbers in this assay, from the lowest: compound 2; then compound 3; then compounds 4 and 1 (each within the scatter of the next).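

In this assay the two rings are not interchangeable: with the same atoms joined differently, pyrimidin-2-yl in place of pyridazin-3-yl gives a 5.0-fold higher number from compound 3 to compound 4 (0.70 log units; beyond the scatter) and so the arrangement of atoms within the ring counts on its own at this position. The lower number of a 7.9-fold lower number from compound 1 to compound 3 (0.90 log units; beyond the scatter) does not carry over to the pyrimidin-2-yl group, which gives a 1.6-fold lower number from compound 1 to compound 4 (0.20 log units; within the scatter) and also stands well short of the 5-chloropyridin-2-yl group in a 32-fold higher number from compound 2 to compound 4 (1.50 log units; beyond the scatter) on the same saturated chain carbon. Nothing available here accounts for the difference between the two rings.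

The compounds shown leave open how pyrazin-2-yl or pyrimidin-4-yl would compare with these rings. They also leave open whether 5-chloropyrimidin-2-yl would stand closer to compound 2 than to compound 4.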